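The source may hold more compounds than are shown below. What is called first, only, known or untested is meant among the compounds shown, and "the series" means these compounds.

Measured so far in a functional assay on UO-31 cells (Homo sapiens) for inhibition, read by sulforhodamine B assay, with a stated time of 48 h (a higher number here means a weaker inhibitor of growth, a lower number a stronger inhibitor of growth), are these:
- compound 1 `COc1cc(-c2nn(-c3cccc(NC(=O)c4cccc(C(F)(F)F)c4)c3)cc2-c2ccncc2)ccc1Cl` gives > 50000 nM as a limit
- compound 2 `COc1cc(-c2nn(-c3cccc(NC(=O)Nc4ccc(Cl)c(Cl)c4)c3)cc2-c2ccncc2)ccc1Cl` gives 4980 nM here
- compound 3 `O=C(Nc1cccc(-n2cc(-c3ccncc3)c(-c3ccc(Cl)c(O)c3)n2)c1)Nc1cc(C(F)(F)F)cc(C(F)(F)F)c1` gives 1900 nM here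

Compound 1 stands at the limit of > 50000 nM in this assay, at which 1 of the 3 values shown sits, and so offers a limit, not a number. Compound 4 `COc1cc(-c2nn(-c3cccc(NC(=O)Nc4ccc(Cl)c(C(F)(F)F)c4)c3)cc2-c2ccncc2)ccc1Cl` is still unmeasured and carries (4-chloro-3-(trifluoromethyl)phenyl)amino in place of 3-(trifluoromethyl)phenyl on a carbonyl carbon. The measured step that bears on this is an at least 10-fold lower number from compound 1 to compound 2 (1.00 log units; beyond the scatter) with (3,4-dichlorophenyl)amino entering at that same carbonyl carbon. A lower number of like size is therefore expected, estimated as an at least 11-fold lower number from compound 1 to compound 4 (1.04 log units; beyond the scatter) in this assay and beyond the scatter. The expected value for compound 4 is 4500 nM (estimated range 1500 nM to 15000 nM).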

Compound 4, concentration for total growth inhibition: 4100 nM
Compound 4: the middle estimate sits 1.1-fold (0.04 log units) above what was measured; low and high end bracket the measured number.
By their numbers in this assay, from the lowest: compound 3; then compounds 4 and 2 (each within the scatter of the next). At a limit, above all of these: compound 1.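

In this assay, a second substituted phenylamino group on the carbonyl carbon gives an at least 12-fold lower number from compound 1 to compound 4 (1.08 log units; beyond the scatter), so the change seen with compound 2 is not confined to the (3,4-dichlorophenyl)amino group. Compound 1 still offers a limit, not a number: the limit of > 50000 nM in this assay, at which 1 of the 4 values shown sits. Trifluoromethyl in place of chloro on the aromatic carbon gives a 1.2-fold lower number from compound 2 to compound 4 (0.08 log units; within the scatter), so this assay does not separate those two groups there. The compounds shown leave open whether an unsubstituted phenylamino group on the carbonyl carbon would give a similar step. They also leave open how a nitrile or a methoxy group would behave on that aromatic carbon.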